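Pyridin-3-yl in place of pyridin-4-yl: expectation for compound 4

The source may hold more compounds than are shown below. What is called first, only, known or untested is meant among the compounds shown, and "the series" means these compounds.

In an ADME assay on Vero cells (Chlorocebus sabaeus) for cytotoxicity, read by resazurin assay, with a stated time of 72 h (on this read-out higher numbers stand for lower toxicity in this test and lower numbers for higher toxicity in this test), compound 1 (`C#CCOc1ccc(C(=O)/C=C/c2cccnc2)c(O)c1`) gives 40000 nM and compound 2 (`C#CCOc1ccc(C(=O)/C=C/c2cccnc2)c(OC)c1`) gives 15000 nM. Compound 3 (`C#CCOc1ccc(C(=O)/C=C/c2ccncc2)c(OCC#C)c1`) gives 10000 nM. Going by the values given here, that value lies within the scatter of compound 2 and beyond the scatter of compound 1, so compound 2 and compound 3 together form the low end of the numbers so far.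

Compound 4 (`C#CCOc1ccc(C(=O)/C=C/c2cccnc2)c(OCC#C)c1`) follows from compound 3 by one exchange: pyridin-3-yl in place of pyridin-4-yl on a double-bonded chain carbon bound to a double-bonded chain carbon. Pyridin-3-yl enters in place of pyridin-4-yl on a double-bonded chain carbon bound to a double-bonded chain carbon. Everything else stays as in compound 3.

Among the compounds with values here, no measured step isolates this exchange. Within the data shown here, the only step available, a 2.7-fold lower number from compound 1 to compound 2 (0.43 log units; beyond the scatter), is modest and concerns methyl in place of hydrogen on an oxygen on an aromatic ring, so it bears on the present change only indirectly. Compound 1 and compound 2 both carry pyridin-3-yl, yet the data offer no matched partner with pyridin-4-yl for either. No change beyond the scatter is therefore expected in this assay, and the expected step is a 1.2-fold higher number from compound 3 to compound 4 (0.08 log units; within the scatter). For compound 4 the estimated value is 12000 nM, with an expected range of 6000 nM to 25000 nM.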

Compound 4, half-maximal cytotoxic concentration: 6000 nM
Compound 4: the middle estimate sits 2.0-fold (0.30 log units) above what was measured; measured number inside the range.
By their numbers in this assay, from the lowest: compounds 4, 3 and 2 (each within the scatter of the next, the first and the last beyond it); then compound 1.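

In this assay, the exchange of pyridin-4-yl for pyridin-3-yl on a double-bonded chain carbon bound to a double-bonded chain carbon is now isolated, and a 1.7-fold lower number from compound 3 to compound 4 (0.22 log units; within the scatter) does not separate the two attachments of the ring. With pyridin-3-yl held fixed, the group on the oxygen on the aromatic ring now forms a three-member set of hydrogen, methyl and propargyl: the earlier 2.7-fold lower number from compound 1 to compound 2 (0.43 log units; beyond the scatter) is joined by a 2.5-fold lower number from compound 2 to compound 4 (0.40 log units; beyond the scatter) and a 6.7-fold lower number from compound 1 to compound 4 (0.82 log units; beyond the scatter), so the numbers fall at each step and the toxicity in this test rises, with propargyl giving the largest step from hydrogen. No measurement on hand accounts for either the flat ring exchange or the fall across the oxygen substituents.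

Pyridin-4-yl appears only in compound 3, so whether the ring exchange stays this small with hydrogen or methyl on that oxygen remains open. Also open, on these data alone, is whether a longer saturated chain, an amine or a carboxylic acid on that oxygen would continue the fall or reverse it.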